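The source may report more compounds than this note shows. Statements on the series, on what has been measured and on what is new or still open speak of the compounds shown alone.

Compound 3 `O=C1/C(=C/c2ccc(F)cc2)CN(S(=O)(=O)c2ccc(F)cc2)C/C1=C\c1ccc(F)cc1` is one of three compounds tested in a functional assay on HepG2 cells (Homo sapiens) for cytotoxicity, read by MTT assay, with a stated time of 24 h; a higher number here means a weaker inhibitor, a lower number a stronger inhibitor. In this assay compound 3 gives 8100 nM. Compound 1 `O=C1/C(=C/c2cccc(F)c2)CN(S(=O)(=O)c2ccc(O[N+](=O)[O-])cc2)C/C1=C\c1cccc(F)c1` gives 8100 nM, level with compound 3 at the digits shown, and together these are the lowest of the three numbers. Compound 2 `O=C1/C(=C/c2ccc(F)cc2)CN(S(=O)(=O)c2ccccc2)C/C1=C\c1ccc(F)cc1` gives 18800 nM. Within the data shown here, the only step between measured compounds that differ in a single place is a 2.3-fold lower number from compound 2 to compound 3 (0.37 log units; beyond the scatter), a modest change. Compound 4 `CC(=O)Nc1ccc(S(=O)(=O)N2C/C(=C\c3ccc(F)cc3)C(=O)/C(=C/c3ccc(F)cc3)C2)cc1` has not yet been measured. It differs from compound 3 in one place: acetamido in place of fluoro on an aromatic carbon. Among the measured compounds shown here, no measured pair shows this exact exchange, so that single step is the closest guide: it shows that a group on an aromatic carbon para to a large group shifts the number only modestly, and nothing measured here tells in which direction an acetamido group would move it. The expected step is therefore a 1.2-fold higher number from compound 3 to compound 4 (0.09 log units; within the scatter), within or close to the scatter. For compound 4 the estimated value in this assay is 10000 nM, with a range from 4000 nM to 25000 nM.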

Compound 4, half-maximal inhibitory concentration: 7400 nM
Beside the measured number, compound 4's estimate is 1.4-fold (0.13 log units) above it, and the stated range covers the measured number.
By their numbers in this assay, from the lowest: compounds 4, 1 and 3 (each within the scatter of the next); then compound 2.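

In this assay, putting acetamido in place of fluoro on an aromatic carbon para to a large group gives a 1.1-fold lower number from compound 3 to compound 4 (0.04 log units; within the scatter). This position therefore accepts acetamido, with 4 heavy atoms and a hydrogen-bond donor, where fluoro has 1 heavy atom and no donor, without a difference that can be told from the scatter. Measured from hydrogen, acetamido gives a 2.5-fold lower number from compound 2 to compound 4 (0.40 log units; beyond the scatter), so two different groups at this position now stand beyond the scatter from hydrogen, and no measurement here explains this result.

As far as these compounds go, it remains open whether an amine, a carboxylic acid or a longer amide chain at this position would stay level with compound 3 and compound 4. Also open, from the compounds shown here alone, is whether acetamido would behave the same way with the outer fluoro groups exchanged.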